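The compounds below may be only part of what the source reports. "The series", "measured", "known", "first", "only" and "open" are said of these compounds alone.

Measured so far in a functional assay on MCF7 cells (Homo sapiens) for cytotoxicity, read by MTT assay; a higher number here means a weaker inhibitor, a lower number a stronger inhibitor:
- compound 1 `CC1(C)C2CCC1(C)C(OC(=O)/C=C/c1ccc(O)c(O)c1[N+](=O)[O-])C2` gives 40700 nM
- compound 2 `O=C(/C=C/c1cc(O)c(O)c([N+](=O)[O-])c1)OCCc1ccccc1` gives 12300 nM
- compound 3 `COc1cc(/C=C/C(=O)OCCc2ccccc2)cc([N+](=O)[O-])c1O` gives > 300000 nM (a limit of the assay, not a number)

Compound 1 at 40700 nM carries the higher of the two true numbers, the other being compound 2 at 12300 nM. The gap between them lies beyond the scatter, with compound 1 the weaker inhibitor of the pair.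

The next compound is compound 4 `CC1(C)C2CCC1(C)C(OC(=O)/C=C/c1ccc(O)c(O)c1)C2`, which is compound 1 with hydrogen in place of nitro on an aromatic carbon. Within the data shown here, the only measured step is an at least 24-fold higher number from compound 2 to compound 3 (1.38 log units; beyond the scatter), which is large. It is a different change, however: methyl in place of hydrogen on an oxygen on an aromatic ring, with the nitro kept on both sides. Among the measured compounds shown here, no measured pair removes a nitro, so that step gives neither a size nor a direction for this change.

In this assay the working expectation is therefore no step beyond the scatter. The estimated step is a 1.5-fold lower number from compound 1 to compound 4 (0.16 log units; within the scatter), and its direction is uncertain. For compound 4 the expected value is 28000 nM, with an estimated range from 8000 nM to 95000 nM.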

Compound 4, half-maximal inhibitory concentration: > 300000 nM
Compound 4: a limit, no number; the forecaster's own chance of this, stated with the estimate: 7%; middle value at least 10-fold (1.02 log units) from the limit.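

In this assay compound 4 gives > 300000 nM, which is a limit of the assay and not a number. With hydrogen in place of nitro on this aromatic carbon, ortho to a hydroxy group and ortho to a large group, the series now has its first measured step for this change, an at least 7.3-fold higher number from compound 1 to compound 4 (0.86 log units; beyond the scatter), so on this core the number rises once the nitro leaves, and the direction is no longer uncertain. Going by these compounds, only a lower bound on the size of this step can be read, and the true number for the compound without the nitro stays unknown: the limit of > 300000 nM in this assay, at which 2 of the 4 values shown sit.

The compounds shown leave open whether the same change gives a step of similar direction on the other ester, the one carried by compound 2, where no pair yet removes a nitro. They also leave open whether the nitro itself is needed at this aromatic carbon, or whether another group there, such as a nitrile or a carboxylic acid, would keep the number close to that of compound 1.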